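Phenyl on the piperazine ring carbon: compound 4 cytotoxicity

The compounds below may be only part of what the source reports. "The series", "measured", "known", "first", "only" and "open" are said of these compounds alone.

The series shares the core of compound 1 `Cc1ccc(-[n+]2noc([O-])c2CN2CCN(C)CC2)cc1`, varied at the amine bound to the saturated chain carbon. In an ADME assay on HEL cells (Homo sapiens) for cytotoxicity (on this read-out lower numbers stand for higher toxicity in this test and higher numbers for lower toxicity in this test), compound 1 gives 100 ug/mL. Compound 2 `Cc1ccc(-[n+]2noc([O-])c2CN2CCCCC2)cc1` gives 100 ug/mL in this assay, and compound 3 `Cc1ccc(-[n+]2noc([O-])c2CN2CCN(c3cccc(Cl)c3Cl)CC2)cc1` gives 20 ug/mL. Compound 1 is level with compound 2, the two together the highest of the three numbers, while compound 3 sits at the lower end.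

Two measured steps start from compound 1. The exchange of the 4-methylpiperazin-1-yl for piperidin-1-yl gave no change at the digits printed from compound 1 to compound 2 (within the scatter). The exchange of methyl for 2,3-dichlorophenyl on the amine nitrogen in the ring gave a 5.0-fold lower number from compound 1 to compound 3 (0.70 log units; beyond the scatter).

Compound 4 `Cc1ccc(-[n+]2noc([O-])c2CN2CCN(C)C(c3ccccc3)C2)cc1` differs from compound 1 by phenyl in place of hydrogen on a saturated ring carbon, keeping the methyl on the ring nitrogen. For the measured compounds named here, no measured step puts an aromatic ring on a saturated ring carbon, so the analogy is loose. Compound 3 shows that an aromatic ring added to the same saturated ring lowers the number, but that aromatic ring carries two chlorines and sits on nitrogen, and compound 2 shows that a small change in the ring leaves the number unchanged. A lowering smaller than that from compound 1 to compound 3, possibly within the scatter, is expected. The step of a 2.0-fold lower number from compound 1 to compound 4 (0.30 log units; within the scatter) is the estimate, giving compound 4 an expected 50 ug/mL, in the range 20 ug/mL to 100 ug/mL.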

Compound 4, minimum cytotoxic concentration: 100 ug/mL
For compound 4 the middle estimate is 2.0-fold (0.30 log units) below the measured one; low and high end bracket the measured number.
By their numbers in this assay, from the lowest: compound 3; then compounds 1, 2 and 4 (each within the scatter of the next).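

In this assay, phenyl on a saturated ring carbon next to the ring nitrogen, with the methyl kept on that nitrogen, gives no change at the digits printed from compound 1 to compound 4 (within the scatter) and adds 6 heavy atoms, so this ring position accepts a six-membered aromatic ring with no change beyond the scatter in this test. Among the compounds shown, an aromatic ring on the amine ring therefore does not by itself go with a lower number: compound 3 shows a lower number with a 5.0-fold lower number from compound 1 to compound 3 (0.70 log units; beyond the scatter) while compound 4 does not, and the two differ in where the ring sits, in its chlorines and in the methyl kept on the ring nitrogen. No measurement in hand bears on why the phenyl on the ring carbon leaves the number in place.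

Still open, going by these compounds, is whether the lower number of compound 3 follows the ring nitrogen as the point of attachment or the two chlorines, a question that a plain phenyl on that nitrogen would address. Also open, on these data alone, is how far the ring carbon's tolerance extends, for example to 2,3-dichlorophenyl, a longer chain such as benzyl, or a carboxylic acid at the same place.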